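The source may report more compounds than this note shows. Statements on the series, on what has been measured and on what is new or still open speak of the compounds shown alone.

Compound 1 `CN(C)CCn1cnnc1-c1cc(Oc2ccc(NC(=O)N/N=C/c3ccc(O)c(F)c3)cc2F)ccn1` gives 3310 nM in a functional assay on HT-29 cells (Homo sapiens) for cytotoxicity, read by MTT assay, with a stated time of 72 h (a higher number here means a weaker inhibitor, a lower number a stronger inhibitor), the highest of the three numbers recorded. Compound 2 `CN(C)CCn1cnnc1-c1cc(Oc2ccc(NC(=O)N/N=C/c3ccc(O)cc3)cc2F)ccn1` gives 1920 nM, with a 1.7-fold lower number from compound 1 to compound 2 (0.24 log units; within the scatter); compound 3 `COc1cc(/C=N/NC(=O)Nc2ccc(Oc3ccnc(-c4nncn4CCN(C)C)c3)c(F)c2)ccc1O` gives 120 nM, with a 28-fold lower number from compound 1 to compound 3 (1.44 log units; beyond the scatter) and a 16-fold lower number from compound 2 to compound 3 (1.20 log units; beyond the scatter). Compound 4 `CN(C)CCn1cnnc1-c1cc(Oc2ccc(NC(=O)N/N=C/c3ccc(Cl)cc3Cl)cc2F)ccn1` differs from compound 1 at the carbon with a double bond to nitrogen: 2,4-dichlorophenyl in place of 3-fluoro-4-hydroxyphenyl on a carbon with a double bond to nitrogen. Among the measured compounds shown here, the measured steps change only a single substituent on that ring; none exchanges the whole aryl group for one that carries no hydroxyl, so they give no direct guide to this step. Compound 4 is therefore expected to stay near compound 1, with a 1.2-fold higher number from compound 1 to compound 4 (0.08 log units; within the scatter) as the estimate, giving 4000 nM within 1500 nM to 12000 nM.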

Compound 4, half-maximal inhibitory concentration: 390 nM
Compound 4: middle estimate off by 10-fold (1.01 log units), on the high side; measured number outside the range, below it.
By their numbers in this assay, from the lowest: compound 3; then compound 4; then compounds 2 and 1 (each within the scatter of the next).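

In this assay, replacing the whole aryl group on this carbon shifts the number beyond the scatter in both directions: there is an 8.5-fold lower number from compound 1 to compound 4 (0.93 log units; beyond the scatter) and a 4.9-fold lower number from compound 2 to compound 4 (0.69 log units; beyond the scatter), so a hydroxyl-bearing ring is not required for a low number, yet there is also a 3.3-fold higher number from compound 3 to compound 4 (0.51 log units; beyond the scatter) (a ring with hydroxyl and methoxy still gives the lowest number). The aryl group as a whole therefore matters here, in a way the single-substituent steps did not reveal. No measurement at hand explains these shifts. As far as these compounds go, whether both chlorines are needed stays open, as does how 4-chlorophenyl, 2-chlorophenyl or an aminophenyl group would behave at this position.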